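A few compounds are considered here, and "the series" means these few. Any claim that something is new, unique, unknown or untested is made for them only; others in the source may bear on it.

Measured compounds in an assay on CHO-K1 cells for antagonist activity at adenosine receptor A1 (Homo sapiens), read by a beta-galactosidase reporter, with stated times of 15 min and 6 h; on this read-out lower numbers stand for stronger inhibition and higher numbers for weaker inhibition:
- compound 1 `Nc1nc(-c2ccco2)nc2sc(CN3CCCC3)cc12`: 6430 nM
- compound 2 `Cc1ccc(-c2nc(N)c3cc(CN4CCCC4)sc3n2)o1`: 620 nM

Compound 1 stands at the highest of the two numbers in this assay. Within the data shown here, the only measured step joins it to compound 2 and is a 10-fold lower number from compound 1 to compound 2 (1.02 log units; beyond the scatter), a change that comes with methyl in place of hydrogen on an aromatic carbon; that step lies beyond the scatter. Compound 3 `Nc1nc(-c2ccco2)nc2sc(CN3CCC(O)CC3)cc12` is the next compound to be measured. It differs from compound 1 in a different place: 4-hydroxypiperidin-1-yl in place of pyrrolidin-1-yl on a saturated chain carbon bound to an aromatic carbon. Among the measured compounds shown here, no measured step touches this part of the shared core, since the single step on record concerns only the methyl on the aromatic carbon and leaves the amine untouched. The data therefore give no basis for expecting a step beyond the scatter in either direction, and the account expects compound 3 to stay close to compound 1. In this assay compound 3 is estimated at 6000 nM, with a range from 2000 nM to 20000 nM. The expected step is a 1.1-fold lower number from compound 1 to compound 3 (0.03 log units; within the scatter), which is within the scatter.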

Compound 3, inhibition constant: 4000 nM
Compound 3: the middle estimate sits 1.5-fold (0.18 log units) above what was measured; low and high end bracket the measured number.
By their numbers in this assay, from the lowest: compound 2; then compounds 3 and 1 (each within the scatter of the next).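

In this assay, 4-hydroxypiperidin-1-yl in place of pyrrolidin-1-yl on a saturated chain carbon bound to an aromatic carbon gives a step within the scatter (a 1.6-fold lower number from compound 1 to compound 3 (0.21 log units; within the scatter)), so this place accepts the entering six-membered ring and its hydroxyl without a step that can be told from repeat measurement. Among these compounds, this is the first measured step at this place, and it stands apart from the methyl step on an aromatic carbon, which lies beyond the scatter (a 10-fold lower number from compound 1 to compound 2 (1.02 log units; beyond the scatter)); the two changes sit in different places, so the pair sets no ranking of one place over the other. No measurement given here explains either result.

The compounds shown leave open whether plain piperidin-1-yl, without the hydroxyl, or morpholin-4-yl, with a ring oxygen, would also stay within the scatter of compound 1, and whether a carboxylic acid on a longer chain at this place would do the same. They also leave open whether the methyl of compound 2 and the 4-hydroxypiperidin-1-yl of compound 3 would add up when carried together on the shared core.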